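A few compounds are considered here, and "the series" means these few. Any claim that something is new, unique, unknown or untested is made for them only; others in the source may bear on it.

Among the measured compounds shown here, in a physicochemical assay for pharmacokinetics, at pH 3 (a lower number here means that the compound disappears faster, a higher number that the compound lasts longer), compound 2 `COc1ccc2cc(C(C)C(=O)OCC(OC(C)=O)C(OC(C)=O)C(OC(C)=O)C(/C=N/[C@H](C(=O)O)C(C)C)OC(C)=O)ccc2c1` gives 44 h, the higher of the two numbers measured so far. Compound 1 `COc1ccc2cc(C(C)C(=O)OCC(OC(C)=O)C(OC(C)=O)C(OC(C)=O)C(/C=N/[C@@H](C)C(=O)O)OC(C)=O)ccc2c1` gives 15 h in this assay. For the measured compounds named here, the only step between them, a 2.9-fold higher number from compound 1 to compound 2 (0.47 log units; beyond the scatter), came with isopropyl in place of methyl on a saturated chain carbon bound to a carbonyl carbon and a double-bonded nitrogen. Compound 3 `COc1ccc2cc(C(C)C(=O)OCC(OC(C)=O)C(OC(C)=O)C(OC(C)=O)C(/C=N/[C@@H](CS)C(=O)O)OC(C)=O)ccc2c1` has not yet been measured; it differs from compound 2 by sulfanylmethyl in place of isopropyl on a saturated chain carbon bound to a carbonyl carbon and a double-bonded nitrogen. That single measured step bears on the new change only loosely: it shows that swapping the group at this carbon can move the half-life beyond the scatter, with the methyl partner sitting at the low end. Because compound 1 gives 15 h with methyl at this carbon, the expected step is a drop, a 2.6-fold lower number from compound 2 to compound 3 (0.41 log units; beyond the scatter), with wide uncertainty. Compound 3 is therefore estimated at 17 h, in a range from 7 h to 40 h.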

Compound 3, half-life: 44 h
For compound 3 the middle estimate is 2.6-fold (0.41 log units) below the measured one; the whole stated range lies below it.
By their numbers in this assay, from the lowest: compound 1; then compounds 2 and 3 (each within the scatter of the next).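

In this assay, the swap of isopropyl for sulfanylmethyl on a saturated chain carbon bound to a carbonyl carbon and a double-bonded nitrogen gives no change at the digits printed from compound 2 to compound 3 (within the scatter), so an all-carbon group and a sulfur-bearing group cannot be told apart here. Sulfanyl in place of hydrogen gives a 2.9-fold higher number from compound 1 to compound 3 (0.47 log units; beyond the scatter), which leaves compound 1, with its methyl, as the only one of the three set apart from the others. No measurement available here explains why these two groups match or why methyl differs.

Open, going by these compounds, is whether the match extends to other groups at this carbon, such as an amine, a carboxylic acid or a longer chain. Also open, on these data alone, is whether any of these would fall with methyl or with isopropyl and sulfanylmethyl.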